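This account rests on a few compounds, and the source may have more. Where it says the series, first, only, none or still open, it means among the compounds named here.

Working notes on the series in an assay on MDA-MB-231 cells for binding affinity to C-X-C chemokine receptor type 4 (Homo sapiens), read by immunofluorescence and microscopy, with stated times of 10 min and 30 min; on this read-out lower numbers stand for an effect already at smaller amounts and higher numbers for an effect only at larger amounts of compound.

Of the compounds shown here, three carry a number so far. Compound 1 `O=C(NCc1ccc(CNS(=O)(=O)c2ccccc2)cc1)c1cccc(Cl)c1` gives 1000 nM, compound 2 `O=C(NCc1ccc(CNS(=O)(=O)c2ccccc2)cc1)c1ccccc1` gives 1 nM, and compound 3 `O=C(NCc1ccc(CNS(=O)(=O)c2ccccc2)cc1)c1ccc(Cl)cc1` gives 100 nM. Compound 3 thus stands second highest of the three: its nearest neighbour is compound 1, a step of a 10-fold lower number from compound 1 to compound 3 (1.00 log units; beyond the scatter) away, and its furthest is compound 2, which lies a 100-fold higher number from compound 2 to compound 3 (2.00 log units; beyond the scatter) away in the other direction. The remaining measured step, a 1000-fold lower number from compound 1 to compound 2 (3.00 log units; beyond the scatter), shows how far apart the two ends of the series sit.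

Compound 4 `O=C(NCc1ccc(CNS(=O)(=O)c2ccccc2)cc1)c1cccc(F)c1` is not yet measured. Its difference from compound 3 is 3-fluorophenyl in place of 4-chlorophenyl on a carbonyl carbon.

Among the compounds with values here, two measured steps bear on this change. The step of a 10-fold lower number from compound 1 to compound 3 (1.00 log units; beyond the scatter) shows that moving a chloro between these two ring positions shifts the number well beyond the scatter, with the 3-position giving the higher number. The step of a 100-fold higher number from compound 2 to compound 3 (2.00 log units; beyond the scatter) shows that a chloro in place of hydrogen on the aromatic carbon also raises the number strongly. Within the data shown here, no measured compound carries fluorine, so the size of the fluorine effect is not covered by the data, and the direction of the step is uncertain. Compound 4 is therefore expected to land at 100 nM, within 10 nM to 1000 nM, which corresponds to an estimated step of no change at the digits printed from compound 3 to compound 4 (within the scatter).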

Compound 4, effective concentration (reported as EC, without a stated level of effect): 100 nM
The estimate for compound 4 equals the measured number at the digits printed; the measured number falls inside the stated range.
By their numbers in this assay, from the lowest: compound 2; then compounds 3 and 4 (each within the scatter of the next); then compound 1.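

Fluoro in place of chloro on an aromatic carbon gives a 10-fold lower number from compound 1 to compound 4 (1.00 log units; beyond the scatter) in this assay, so at this ring position the identity of the halogen moves the number, a change the chloro compounds alone could not show. Adding a fluoro to the unsubstituted phenyl ring gives a 100-fold higher number from compound 2 to compound 4 (2.00 log units; beyond the scatter), so the rise on adding a halogen to the ring of compound 2 is not limited to chloro, and none of the three halogen-bearing compounds goes against this. With 3-fluorophenyl in place of 4-chlorophenyl on the carbonyl carbon, the result is no change at the digits printed from compound 3 to compound 4 (within the scatter) even though both the halogen and its ring position differ, so a change in one can be offset when the other changes as well.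

Still open, going by these compounds, is how 4-fluorophenyl, or a methoxy group, an amine or a carboxylic acid on this ring, would compare with the unsubstituted phenyl of compound 2 at 1 nM and whether any of them would keep a number that low. No measurement at hand accounts for any of these shifts.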